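Amino for Chloro on a Purine Core: Predicting Compound 4

A few compounds are considered here, and "the series" means these few. Any claim that something is new, unique, unknown or untested is made for them only; others in the source may bear on it.

Measured compounds:
compound 1 `Nc1nc(Cl)c2ncn(Cc3ccc(CCl)cc3)c2n1`: 63100 nM
compound 2 `ClCc1cccc(Cn2cnc3c(Cl)nc(Cl)nc32)c1`: 17000 nM
compound 3 `ClCc1ccc(Cn2cnc3c(Cl)nc(Cl)nc32)cc1`: 97700 nM

All three were tested in a functional assay on NCI-H522 cells (Homo sapiens) for cytotoxicity, read by sulforhodamine B assay, with a stated time of 48 h; a lower number here means that less compound is tolerated, a higher number that more compound is tolerated. Compound 2 gives the lowest of the three numbers, and both other compounds stand beyond the scatter from it. Compound 2 and compound 3 share the same atoms joined differently; how the two cores differ is not broken down here.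

Compound 1 arises from compound 3 by one change, (amino in place of chloro on an aromatic carbon), and the step is a 1.5-fold lower number from compound 3 to compound 1 (0.19 log units; within the scatter). The same change turns compound 2 into the unmeasured compound 4 `Nc1nc(Cl)c2ncn(Cc3cccc(CCl)c3)c2n1`, namely (amino in place of chloro on an aromatic carbon). Because the earlier step of a 1.5-fold lower number from compound 3 to compound 1 (0.19 log units; within the scatter) stayed within the scatter, compound 4 is expected to land close to compound 2, with an expected step of a 1.5-fold lower number from compound 2 to compound 4 (0.19 log units; within the scatter). The estimate for compound 4 in this assay is 11000 nM, between 5000 nM and 30000 nM.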

Compound 4, concentration lethal to 50% of the cells: 81300 nM
Estimate against measurement, compound 4: 7.4-fold (0.87 log units) below; the measured number lies above the stated range.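

In this assay, amino in place of chloro on the core of compound 2 gives a 4.8-fold higher number from compound 2 to compound 4 (0.68 log units; beyond the scatter). The size of this change therefore does not carry over from one core to the other in these two pairs: the same change on two cores in this assay, a 1.5-fold lower number (0.19 log units; within the scatter) from compound 3 to compound 1 and a 4.8-fold higher number (0.68 log units; beyond the scatter) from compound 2 to compound 4, 7.4-fold (0.87 log units) apart, beyond the scatter of two such steps This does not show what makes the two steps differ, and two pairs set no rule for the series.

The compounds shown leave open how a third core would respond to the same change. They also leave open whether a methylamino or methoxy group, on the aromatic carbon between two ring nitrogen atoms, would follow the step seen on either core.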